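The source may report more compounds than this note shows. Statements on the series, on what has been measured and on what is new or still open speak of the compounds shown alone.

Measured compounds:
- compound 1 `O=C(CCCCCc1ccc(F)c(Cl)c1)N1CCOC1=O`: 26 nM
- compound 2 `COc1cccc(CCCCCC(=O)N2CCOC2=O)c1`: 16300 nM
- compound 3 `O=C(CCCCCc1ccc(O)cc1)N1CCOC1=O`: 61 nM

Of the compounds shown here, three sharing one core have been tested in an assay on HEK293 cells for inhibition of N-acylethanolamine-hydrolyzing acid amidase (Rattus norvegicus), read by LC-MS, with a stated time of 30 min; a lower number here means a stronger inhibitor, a higher number a weaker inhibitor. Compound 1 gives 26 nM and compound 3 gives 61 nM, while compound 2 gives 16300 nM, the highest number of the three; both other compounds lie far beyond the scatter from it, so compound 2 is clearly the weakest inhibitor shown.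

For the measured compounds named here, the next compound, compound 4 `Cc1cccc(CCCCCC(=O)N2CCOC2=O)c1`, changes only one thing relative to compound 2: methyl in place of methoxy on an aromatic carbon. The methyl keeps the same place on the six-membered aromatic ring of carbon only, meta to a large group, but the oxygen of the methoxy is gone.

Going by the values given here, no directly measured pair here shows what such a swap does, so the expectation rests on the spread of the three values alone. Compound 2 stands so far above compound 1 and compound 3 that there is more room for a lower number than for a higher one, and a step beyond the scatter toward stronger inhibition is plausible, though a step within the scatter cannot be ruled out. Compound 4 is therefore expected to give about 4000 nM in this assay, most likely between 600 nM and 16000 nM, a change of a 4.1-fold lower number from compound 2 to compound 4 (0.61 log units; beyond the scatter).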

Compound 4, half-maximal inhibitory concentration: 350 nM
Compound 4: the middle estimate sits 11-fold (1.06 log units) above what was measured; the measured number lies below the stated range.
By their numbers in this assay, from the lowest: compound 1; then compound 3; then compound 4; then compound 2.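

Swapping methoxy for methyl gives a 47-fold lower number from compound 2 to compound 4 (1.67 log units; beyond the scatter) in this assay, a large step well beyond the scatter and the first direct reading of a single change in this set. The rest of the molecule stays the same, so the very high number of compound 2 is tied to the methoxy at this place, meta to a large group, and not to the shared core or the chain alone: with a methyl there, compound 4 gives 350 nM. Nothing measured here explains why removing the oxygen of the methoxy has so large an effect on the number.

The compounds shown leave open whether a bare hydrogen, an ethyl or an amine at this same place would give a number closer to that of compound 4 or to that of compound 2. They also leave open whether the same swap would give a step of similar size on a version of the molecule with a longer chain, or with the methoxy and methyl at another place on the aromatic ring.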